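The compounds below may be only part of what the source reports. "The series", "measured", "known", "first", "only" and "open" are said of these compounds alone.

Working notes on the series in a functional assay on cells (Erythrocyte, Rattus norvegicus) for inhibition, read by hemolysis, with a stated time of 1 h; on this read-out higher numbers stand for weaker inhibition and lower numbers for stronger inhibition. Compound 1 `COc1cc(OC)c(OC)cc1/C=C/C(=O)c1ccc(C)cc1` gives 2.24 ug/mL and compound 2 `COc1cc(OC)c(OC)cc1/C=C/C(=O)c1ccc(F)cc1` gives 2.22 ug/mL. Among the compounds with values here, these two numbers lie within the scatter of each other, so compound 2 stands level with its only measured neighbour. The next change leads to compound 3 `COc1cc(OC)c(OC)cc1/C=C/C(=O)c1ccc([N+](=O)[O-])cc1`: nitro in place of fluoro on an aromatic carbon. Within the data shown here, the only measured step bearing on it is a 1.0-fold lower number from compound 1 to compound 2 (0.00 log units; within the scatter), which stayed within the scatter. Among the measured compounds shown here, this is a single step, and no measured compound yet carries a nitro group, so the evidence is thin. No shift beyond the scatter is therefore expected in this assay, and neither direction is favoured. The expected step is a 1.0-fold lower number from compound 2 to compound 3 (0.00 log units; within the scatter). The estimated value for compound 3 is 2.2 ug/mL, with an expected range from 0.8 ug/mL to 6 ug/mL.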

Compound 3, half-maximal inhibitory concentration: 2.34 ug/mL
Estimate against measurement, compound 3: 1.1-fold (0.03 log units) below; low and high end bracket the measured number.
By their numbers in this assay, from the lowest: compounds 2, 1 and 3 (each within the scatter of the next).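

Nitro, a group with more heavy atoms and hydrogen-bond acceptors than fluoro, sits at the same place on an aromatic carbon, para to a large group, and this assay shows a 1.1-fold higher number from compound 2 to compound 3 (0.02 log units; within the scatter) and a 1.0-fold higher number from compound 1 to compound 3 (0.02 log units; within the scatter) as the comparison with methyl. The earlier pair covered only methyl and fluoro; with nitro added, all three groups at this position stand level, and no replacement among them has yet moved the number beyond the scatter. Nothing measured alongside these numbers speaks to the reason for this level result.

On these data alone, whether an amine, a carboxylic acid or a longer chain at this position would stay level remains open. Also open, as far as these compounds go, is whether changes elsewhere on the shared core, such as to its methoxy groups, would move the number.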